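A few compounds are considered here, and "the series" means these few. Any claim that something is new, unique, unknown or untested is made for them only; others in the source may bear on it.

Of the compounds shown here, two that share one core have been tested in a functional assay on KB cells (Homo sapiens) for cytotoxicity, read by MTT assay, with a stated time of 72 h; a higher number here means that more compound is needed for the effect, a lower number that less compound is needed. Compound 1 `O=C1/C(=C\c2cc3ccccc3nc2Cl)c2ccccc2N1c1c(Cl)cccc1Cl` carries no methyl on the six-membered aromatic ring of carbon only that sits in its fused system of two rings, and in this assay compound 1 gives 10 ug/mL. Compound 2 `Cc1ccc2nc(Cl)c(/C=C3\C(=O)N(c4c(Cl)cccc4Cl)c4ccccc43)cc2c1C` carries two methyl groups on that ring, and in this assay compound 2 gives 10 ug/mL. Compound 2 therefore stands level with compound 1 at the digits shown; the two readings lie within the usual scatter of each other, so no order can be drawn between them.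

Compound 3 `Cc1ccc2nc(Cl)c(/C=C3\C(=O)N(c4c(Cl)cccc4Cl)c4ccccc43)cc2c1` has not yet been measured. It differs from compound 2 in one place: hydrogen in place of methyl on an aromatic carbon, in words hydrogen in place of methyl on an aromatic carbon. Within the data shown here, no measured pair shows this exact change. What is known is that compound 1, without methyl, gives 10 ug/mL, and that compound 2, with two methyls, gives 10 ug/mL, which is within the scatter of that. Removing one of the two methyls is expected to make no difference beyond the scatter, so the step from compound 2 to compound 3 is estimated at no change at the digits printed from compound 2 to compound 3 (within the scatter). Compound 3 is expected to give about 10 ug/mL, within a likely range from 5 ug/mL to 20 ug/mL.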

Compound 3, concentration for half-maximal effect: 100 ug/mL
Estimate against measurement, compound 3: 10-fold (1.00 log units) below, and the stated range ends below it.
By their numbers in this assay, from the lowest: compounds 1 and 2 (each within the scatter of the next); then compound 3.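

In this assay, replacing the methyl that sits ortho to a fused ring and ortho to a methyl group with hydrogen gives a 10-fold higher number from compound 2 to compound 3 (1.00 log units; beyond the scatter), so this single aromatic carbon matters, even though the level readings of the compounds with no methyl and two methyls gave no sign of it. Seen from the compound with no methyl on this ring, adding one methyl gives a 10-fold higher number from compound 1 to compound 3 (1.00 log units; beyond the scatter), which means that more compound is needed with one methyl than with either none or two, and the effect of a methyl here therefore depends on whether the other methyl is present. Nothing in the available data explains this dependence.

The compounds shown leave open whether a lone methyl on the carbon that has just lost its group would behave like the lone methyl in compound 3. They also leave open whether an ethyl group, a methoxy group or an amine on this carbon would give a reading closer to that of compound 2 or to that of compound 3.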